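This account rests on a few compounds, and the source may have more. Where it says the series, first, only, none or still open, it means among the compounds named here.

- compound 1 `CCc1cc(CN2CC(C(=O)O)C2)sc1-c1ncc(-c2ccc(OC(C)C)c(C)c2)s1`: 0.07 mg/kg
- compound 2 `CCc1cc(-c2cnc(-c3sc(CN4CC(C(=O)O)C4)cc3CC)s2)ccc1OC(C)C`: 0.16 mg/kg
- compound 3 `CCc1cc(CN2CC(C(=O)O)C2)sc1-c1ncc(-c2ccc(OC(C)C)c(C(C)C)c2)s1`: 0.53 mg/kg

In a functional assay on the whole organism (spleen, spleen, strain LEW) for inhibition, with Rattus norvegicus as the target, with a stated time of 4 days (on this read-out lower numbers stand for an effect already at smaller amounts and higher numbers for an effect only at larger amounts of compound), compound 1 has the lowest number of the three, at 0.07 mg/kg. Compound 4 `CCc1cc(CN2CC(C(=O)O)C2)sc1-c1ncc(-c2ccc(O[C@@H](C)CC)c(C)c2)s1` has not yet been measured. It differs from compound 1 by methyl in place of hydrogen on a saturated chain carbon, two bonds along the chain from an oxygen on an aromatic ring, which turns isopropoxy into sec-butoxy.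

For the measured compounds named here, no measured step changes the isopropoxy group itself, so the evidence is indirect. The closest guide is what happened when a different alkyl group was enlarged. There is a 2.3-fold higher number from compound 1 to compound 2 (0.36 log units; beyond the scatter), then a 3.3-fold higher number from compound 2 to compound 3 (0.52 log units; beyond the scatter), and taken together a 7.6-fold higher number from compound 1 to compound 3 (0.88 log units; beyond the scatter). Each of these enlargements raised the number, so a larger group did not help in these three compounds. Going by these compounds, whether the same holds for the isopropoxy group is untested, and a step of similar direction but modest size seems the fair expectation. The expected step, a 1.9-fold higher number from compound 1 to compound 4 (0.27 log units; within the scatter), is small and leans upward, and it may not clear the usual scatter. For compound 4 the estimated value is 0.13 mg/kg, with an expected range from 0.05 mg/kg to 0.4 mg/kg.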

Compound 4, dose for 50% inhibition: 0.32 mg/kg
Beside the measured number, compound 4's estimate is 2.5-fold (0.39 log units) below it; measured number inside the range.
By their numbers in this assay, from the lowest: compound 1; then compounds 2, 4 and 3 (each within the scatter of the next, the first and the last beyond it).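

In this assay, the isopropoxy group proves sensitive to change: going to sec-butoxy, which puts methyl in place of hydrogen on a saturated chain carbon, two bonds along the chain from an oxygen on an aromatic ring, gives a 4.6-fold higher number from compound 1 to compound 4 (0.66 log units; beyond the scatter). The earlier compounds shown here all carry isopropoxy, so they could say nothing about this position, and the result now shows that a single added carbon here is enough to move the number beyond the scatter. The added methyl also costs about as much here as it does on another alkyl chain in the series, so the effect is not unique to this position among the compounds shown: the same change on two cores in this assay, a 3.3-fold higher number (0.52 log units; beyond the scatter) from compound 2 to compound 3 and a 4.6-fold higher number (0.66 log units; beyond the scatter) from compound 1 to compound 4, 1.4-fold (0.14 log units) apart, within the scatter of two such steps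

The compounds shown leave open whether a smaller ethoxy or methoxy group at this position would lower the number or raise it, and so whether isopropoxy is the best fit or simply the point where the rise begins. Only one mirror-image form of sec-butoxy appears, so the other form could behave differently, and a whole-organism read-out does not reveal what lies behind the rise.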